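A methylpiperazine in place of trifluoromethyl

The source may report more compounds than this note shows. Statements on the series, on what has been measured and on what is new or still open speak of the compounds shown alone.

Compound 2 `Cc1cn(-c2cc(NC(=O)c3ccc(C)c(Oc4ccccc4)c3)cc(C(F)(F)F)c2)cn1` stands highest of the two numbers in an ADME assay on the whole organism (Mus musculus, strain CD1), read by LC-MS, using cassette dosing, with a stated time of 24 h, at a dose of 0.4 mg/kg by the intravenous route (a higher number here means more compound in the circulation at the dose given, a lower number less compound in the circulation), giving 508 ng.h/mL; compound 1 `Cc1cn(-c2cc(NC(=O)c3ccc(C)c(Nc4nccc(-c5ccccc5)n4)c3)cc(N3CCN(C)CC3)c2)cn1` gives 189 ng.h/mL in this assay, a gap beyond the scatter. Compound 3 `Cc1cn(-c2cc(NC(=O)c3ccc(C)c(Oc4ccccc4)c3)cc(N3CCN(C)CC3)c2)cn1` differs from compound 2 by 4-methylpiperazin-1-yl in place of trifluoromethyl on an aromatic carbon. Among the compounds with values here, no measured pair isolates this change; the only other compound with a 4-methylpiperazin-1-yl group, which differs from compound 3 elsewhere as well, is compound 1, and compound 1 gives 189 ng.h/mL. A downward step is therefore expected, a 2.5-fold lower number from compound 2 to compound 3 (0.40 log units; beyond the scatter), beyond the scatter. Compound 3 is estimated at 200 ng.h/mL, within 80 ng.h/mL to 500 ng.h/mL.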

Compound 3, area under the concentration-time curve: 338 ng.h/mL
Compound 3: the middle estimate sits 1.7-fold (0.23 log units) below what was measured; measured number inside the range.
By their numbers in this assay, from the lowest: compounds 1, 3 and 2 (each within the scatter of the next, the first and the last beyond it).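

With the rest of the structure held fixed, 4-methylpiperazin-1-yl in place of trifluoromethyl on this aromatic carbon gives a 1.5-fold lower number from compound 2 to compound 3 (0.18 log units; within the scatter) in this assay. The exchange, which brings in a six-membered non-aromatic ring, thus leaves the number within the scatter, something compound 1 and compound 2 could not show, as they differ in more than one place. On these data alone, whether a morpholine or an open-chain amine such as dimethylamino would behave alike on this carbon stays open, as does the same exchange on the core of compound 1. Nothing at hand bears on what lies behind this result.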